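The source may report more compounds than this note shows. Statements on the series, on what has been measured and on what is new or still open speak of the compounds shown alone.

Working notes on the sulfonyl series. Compound 3 `Cc1ccc2ncc(S(=O)(=O)c3ccc(F)c(Cl)c3)c(N3CCC(C)CC3)c2c1` is the reference here; in an assay on isolated protein for displacement of a labelled ligand from metabotropic glutamate receptor 5 (Homo sapiens), with a stated time of 60 min, tested at 1 uM (on this read-out lower numbers stand for less inhibition and higher numbers for more inhibition at the one concentration tested (going by the name of the read-out)), compound 3 gives 93%. Compound 2 `CC1CCN(c2c(S(=O)(=O)c3cc(F)cc(F)c3)cnc3ccc(Cl)cc23)CC1` sits level with it at the digits shown, within the scatter: in this assay compound 2 gives 93%. Compound 1 `Cc1ccc2ncc(S(=O)(=O)c3ccc(Cl)cc3)c(N3CCC(C)CC3)c2c1` is the one that lies clearly lower, and in this assay compound 1 gives 79%. For the measured compounds named here, the only single-place step measured so far is a number 14 percentage points higher from compound 1 to compound 3 (beyond the scatter), a modest gain that lies beyond the scatter.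

Compound 4 `Cc1ccc2ncc(S(=O)(=O)c3cc(F)cc(F)c3)c(N3CCC(C)CC3)c2c1` has not been measured. Against compound 3 the change is 3,5-difluorophenyl in place of 3-chloro-4-fluorophenyl on a sulfonyl sulfur. The step from compound 1 to compound 3 bears on this only loosely, since it too swaps the aryl group on the sulfonyl sulfur, and it was modest in size. More directly, compound 2 already carries 3,5-difluorophenyl on the sulfonyl sulfur, on a different core, and the values of compound 2 and compound 3 show no gap between them. The expectation is therefore that compound 4 stays about level with compound 3, with a number 3 percentage points lower from compound 3 to compound 4 (within the scatter) not beyond the scatter. The estimate for compound 4 in this assay is 90%, with a range from 78% to 98%.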

Compound 4, a percentage reported as inhibition, at one concentration (the size of the read-out at that concentration, not a potency): 72%
For compound 4 the middle estimate is 18 percentage points above the measured one; the whole stated range lies above it.
By their numbers in this assay, from the lowest: compounds 4 and 1 (each within the scatter of the next); then compounds 2 and 3 (each within the scatter of the next).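

The aryl group on the sulfonyl sulfur is not interchangeable on this core: in this assay there is a number 21 percentage points lower from compound 3 to compound 4 (beyond the scatter) when 3,5-difluorophenyl stands in place of 3-chloro-4-fluorophenyl, so the two fluorines of the entering group do not carry the result of the leaving chlorine and fluorine. The 3,5-difluorophenyl group also gives no fixed result across cores, since methyl in place of chloro on an aromatic carbon comes with a number 21 percentage points lower from compound 2 to compound 4 (beyond the scatter) and that one change on the core is enough to move the read-out beyond the scatter. Against this, a number 7 percentage points lower from compound 1 to compound 4 (within the scatter) leaves 3,5-difluorophenyl and 4-chlorophenyl not separated on this core, so among the three aryl groups on it only 3-chloro-4-fluorophenyl stands clear of the other two.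

Going by these compounds, whether a methoxy group or a nitrile on the aryl group on the sulfonyl sulfur would reach the result of 3-chloro-4-fluorophenyl, and whether chloro in place of methyl on an aromatic carbon gives a gain with other aryl groups, stays open. Nothing in the data available gives a reason for the size of these steps.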